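Replacing the amino substituent of compound 1 by methoxy

The source may hold more compounds than are shown below. What is called first, only, known or untested is meant among the compounds shown, and "the series" means these compounds.

compound 1 `C=C1[C@H](C)CCC[C@]1(C)CC/C(C)=C/CC1=C(O)C(=O)C=C(N[C@@H](C(=O)O)C(C)C)C1=O` gives 3.4 ug/mL as a number
compound 2 `CC1=CCC[C@](C)(CC/C(C)=C/CC2=C(O)C(=O)C=C(N[C@@H](C(=O)O)[C@@H](C)O)C2=O)[C@@H]1C` gives > 10 ug/mL as a limit
compound 3 `CC1=CCC[C@](C)(CC/C(C)=C/CC2=C(O)C(=O)C=C(N[C@H](CO)C(=O)O)C2=O)[C@@H]1C` gives > 10 ug/mL as a limit

Within the data shown here, in an ADME assay on L1210 cells (Mus musculus) for cytotoxicity, with a stated time of 48 h (on this read-out higher numbers stand for weaker inhibition and lower numbers for stronger inhibition), compound 1 gives 3.4 ug/mL and this is the only true number in the set. Compound 2 and compound 3 stand at limits of the assay. What these two values give is the limit of > 10 ug/mL in this assay, at which 2 of the 3 values shown sit, and no more.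

Compound 4 `C=C1[C@H](C)CCC[C@]1(C)CC/C(C)=C/CC1=C(O)C(=O)C=C(OC)C1=O` is still unmeasured. The change is methoxy in place of (1-carboxy-2-methylpropyl)amino on a double-bonded ring carbon and it puts methoxy in place of (1-carboxy-2-methylpropyl)amino on a double-bonded ring carbon. Among the measured compounds shown here, the only step between measured compounds is a step that the two limits leave unreadable from compound 2 to compound 3 and it gives no size for this change. The expectation therefore rests on compound 1 at 3.4 ug/mL as its sole anchor. No move beyond the scatter is expected in this assay and no firm direction can be claimed. The expected step is a 1.3-fold lower number from compound 1 to compound 4 (0.12 log units; within the scatter) and this is an estimate only. For compound 4 the estimated value is 2.6 ug/mL with an expected range from 0.8 ug/mL to 8 ug/mL around it.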

Compound 4, half-maximal inhibitory concentration: 2.4 ug/mL
Beside the measured number, compound 4's estimate is 1.1-fold (0.03 log units) above it; low and high end bracket the measured number.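

In this assay the change gives a 1.4-fold lower number from compound 1 to compound 4 (0.15 log units; within the scatter). Among these compounds, this is the first readable size for any change in the set, and it concerns the double-bonded ring carbon two ring bonds from the ring atom that bears a large group. On the core of compound 1, the whole (1-carboxy-2-methylpropyl)amino group, with its carboxylic acid, its defined stereocentre and its hydrogen-bond donors, can thus give way to the much smaller methoxy without a move beyond the scatter.

Compound 2 and compound 3 each stand at a limit, and the step between them cannot be read: the limit of > 10 ug/mL in this assay, at which 2 of the 4 values shown sit.

On these data alone, whether a plain amine, a hydroxy group or a longer alkoxy chain such as butoxy on this carbon would keep the number within the scatter stays open.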